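The source may report more compounds than this note shows. Statements on the series, on what has been measured and on what is new or still open speak of the compounds shown alone.

Three compounds share one core and differ only in the group carried on an amine nitrogen in a ring. Compound 1 `CC(C)(C)c1cc(NC(=O)[C@@H]2CCCCN2Cc2ccc(Cl)cc2)no1` gives 0.15 h in an ADME assay (liver) for metabolic stability, with Liver microsome (Homo sapiens) as the target, read by LC-MS, using microsomes and NADPH, tested at 1 uM; a higher number here means that the compound lasts longer, a lower number that the compound disappears faster. Compound 2 `CC(C)(C)c1cc(NC(=O)[C@@H]2CCCCN2C2CC2)no1` gives 0.183 h, and compound 3 `CC(C)CN1CCCC[C@H]1C(=O)Nc1cc(C(C)(C)C)on1` gives 0.1 h, the low end of the three numbers, though its gaps to both other compounds lie within the scatter. Compound 4 `CC(C)(C)c1cc(NC(=O)[C@@H]2CCCCN2C2CCOCC2)no1` has not yet been tested; it carries oxan-4-yl in place of isobutyl on an amine nitrogen in a ring. The earlier changes at that same nitrogen, a 1.8-fold lower number from compound 2 to compound 3 (0.26 log units; within the scatter) and a 1.2-fold higher number from compound 1 to compound 2 (0.09 log units; within the scatter), both stayed within the scatter, so no shift beyond the scatter is expected here either. The step expected from compound 3 to compound 4 is a 1.3-fold higher number from compound 3 to compound 4 (0.11 log units; within the scatter). The estimated half-life of compound 4 is 0.13 h, with a range from 0.06 h to 0.3 h.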

Compound 4, half-life in the Liver microsome assay: 0.317 h
Compound 4: middle estimate off by 2.4-fold (0.39 log units), on the low side; measured number above the stated range.
By their numbers in the Liver microsome assay, from the lowest: compounds 3, 1, 2 and 4 (each within the scatter of the next, the first and the last beyond it).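

At this nitrogen no earlier change moved the number in the Liver microsome assay beyond the scatter, but oxan-4-yl does so against two groups, with a 3.2-fold higher number from compound 3 to compound 4 (0.50 log units; beyond the scatter) and a 2.1-fold higher number from compound 1 to compound 4 (0.32 log units; beyond the scatter), though not against cyclopropyl, with a 1.7-fold higher number from compound 2 to compound 4 (0.24 log units; within the scatter). In a physicochemical assay for solubility, read by HPLC, at pH 6.8 (a higher number here means a more soluble compound, a lower number a less soluble compound), compound 3 gives 32 ug/mL and compound 4 gives 74 ug/mL. Oxan-4-yl in place of isobutyl also raises the number in the physicochemical assay: the measured solubility of compound 3, 32 ug/mL, and of compound 4, 74 ug/mL, a 2.3-fold higher number (0.36 log units; beyond the scatter)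

Whether the oxygen or the ring of oxan-4-yl accounts for these rises stays open. A cyclohexyl group, the same ring with carbon in place of the oxygen, would separate the two.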